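Fluoro on the N-aryl ring: compound 3 to compound 4

A few compounds are considered here, and "the series" means these few. Any claim that something is new, unique, unknown or untested is made for them only; others in the source may bear on it.

Compound 3 `COc1cc2c(Oc3ccc(NC(=O)c4nn(-c5ccccc5)c(=O)c5ccccc45)cc3F)ccnc2cc1OCCCN1CCCCC1` gives 590 nM in a functional assay on MKN-45 cells (Homo sapiens) for cytotoxicity, read by MTT assay, with a stated time of 72 h (on this read-out higher numbers stand for weaker inhibition and lower numbers for stronger inhibition), the highest of the three numbers. Compound 1 `COc1cc2c(Oc3ccc(NC(=O)c4nn(-c5ccccc5F)c(=O)c5ccccc45)cc3F)ccnc2cc1OCCCN1CCCC1` gives 140 nM and compound 2 `COc1cc2c(Oc3ccc(NC(=O)c4nn(-c5ccccc5F)c(=O)c5ccccc45)cc3F)ccnc2cc1OCCCN1CCN(C)CC1` gives 210 nM; both lie beyond the scatter below compound 3, but each differs from it in two places. Within the data shown here, the only single-point step, a 1.5-fold higher number from compound 1 to compound 2 (0.18 log units; within the scatter), concerns the amine on the chain alone. Compound 4 `COc1cc2c(Oc3ccc(NC(=O)c4nn(-c5ccccc5F)c(=O)c5ccccc45)cc3F)ccnc2cc1OCCCN1CCCCC1` is compound 3 with fluoro in place of hydrogen on an aromatic carbon. Among the measured compounds shown here, no measured step covers this change in isolation; the lower numbers of compound 1 and compound 2, which both carry the fluoro, are the only hint, and the amine differs as well. The step from compound 3 to compound 4 is therefore expected to be modest, a 1.8-fold lower number from compound 3 to compound 4 (0.27 log units; within the scatter), leaning toward a lower number. Compound 4 is estimated at 320 nM, with a range of 120 nM to 850 nM.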

Compound 4, half-maximal inhibitory concentration: 350 nM
The estimate for compound 4 lay 1.1-fold (0.04 log units) below the measured number; low and high end bracket the measured number.
By their numbers in this assay, from the lowest: compounds 1, 2, 4 and 3 (each within the scatter of the next, the first and the last beyond it).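

In this assay, phenyl to 2-fluorophenyl now has a reading of its own: with piperidin-1-yl on the chain, fluoro in place of hydrogen, ortho to a large group, stays within the scatter (a 1.7-fold lower number from compound 3 to compound 4 (0.23 log units; within the scatter)), so no effect of the fluoro can be claimed. Among the 2-fluorophenyl compounds, the change from 4-methylpiperazin-1-yl also stays within the scatter (a 1.7-fold higher number from compound 2 to compound 4 (0.22 log units; within the scatter)), whereas the change from pyrrolidin-1-yl goes beyond it (a 2.5-fold higher number from compound 1 to compound 4 (0.40 log units; beyond the scatter)). Nothing on hand accounts for these steps. Open: whether the fluoro step holds with pyrrolidin-1-yl or 4-methylpiperazin-1-yl on the chain, and how chloro in place of fluoro, a morpholin-4-yl amine or a longer chain would read.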